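The source may report more compounds than this note shows. Statements on the series, on what has been measured and on what is new or still open speak of the compounds shown alone.

Four compounds are compared here, all built on closely related sugar-linked cores. Compound 1 `O=c1ccn([C@@H]2O[C@H](COP(=O)(O)OP(=O)(O)OP(=O)(O)O)[C@@H](O)[C@H]2O)c(=S)[nH]1` and compound 2 `O=c1ccn([C@@H]2O[C@H](COP(=O)(O)OP(=O)(O)O)[C@@H](O)[C@H]2O)c(=S)[nH]1` differ in one place: a hydrogen atom in place of a group of 4 heavy atoms (3 oxygen, 1 phosphorus; no ring), on an oxygen. In an in vitro functional assay on 1321-N1 cells for agonist activity at P2Y purinoceptor 4 (Homo sapiens) (on this read-out higher numbers stand for an effect only at larger amounts of compound and lower numbers for an effect already at smaller amounts), compound 1 gives 1770 nM. For compound 2 this assay reports only a limit, > 1000 nM, which means the number itself was not resolved. The resulting step, a step that the limit leaves unreadable from compound 1 to compound 2, is therefore unreadable; what is known rests on (the limit of > 1000 nM in this assay, at which 1 of the 3 values shown sits).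

Compound 3 `Cc1cc(=O)n([C@@H]2O[C@H](COP(=O)(O)OP(=O)(O)O)[C@@H](O)[C@H]2O)c(=O)[nH]1` carries a different core; the difference between the two cores is not broken down here. For compound 3 this assay again reports only a limit, > 100000 nM, as stated in the limit of > 100000 nM in this assay, at which 1 of the 3 values shown sits.

Compound 4 `Cc1cc(=O)n([C@@H]2O[C@H](COP(=O)(O)O)[C@@H](O)[C@H]2O)c(=O)[nH]1` has not been measured. It differs from compound 3 by the same kind of change seen between compound 1 and compound 2: a hydrogen atom in place of a group of 4 heavy atoms (3 oxygen, 1 phosphorus; no ring), on an oxygen. The place of the change is described in the same words for both pairs.

Because compound 3 already sits at the limit > 100000 nM, and because the earlier step that the limit leaves unreadable from compound 1 to compound 2 gives no readable size for this change, the expectation for compound 4 leans on the starting point alone. The step from compound 3 to compound 4 is estimated to be a step that the limit leaves unreadable from compound 3 to compound 4, and compound 4 is expected to give 300000 nM in this assay, most probably reported again only as a limit, with a range from 100000 nM to 1000000 nM.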

Compound 4, half-maximal effective concentration: > 100000 nM
Compound 4 gave a limit, no number; the forecaster's own chance of this, stated with the estimate: 90%; the middle value is on the limit's open side.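

In this assay, compound 3 and compound 4 are both reported only as limits, not as numbers, so no size can be read for the step between them. The compounds shown leave open how much replacing the group of 4 heavy atoms with a hydrogen atom changes the response, both in this pair and in compound 1 and compound 2, and where compound 3 and compound 4 truly lie.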